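Cyano in Place of Fluoro on Two Different Cores

The compounds below may be only part of what the source reports. "The series", "measured", "known", "first", "only" and "open" are said of these compounds alone.

In a functional assay on cells for positive allosteric modulation of metabotropic glutamate receptor 2 (Homo sapiens), read by fluorescence and calcium flux, with a stated time of 30 min (a higher number here means that more compound is needed for the effect, a lower number that less compound is needed), compound 1 `Fc1cc(Cl)ccc1-c1ccc(Cn2nnc3c(F)cccc32)cn1` gives 27 nM, and compound 2 `N#Cc1cccc2c1nnn2Cc1ccc(-c2ccc(Cl)cc2F)nc1` gives 33 nM. The change between them, (cyano in place of fluoro on an aromatic carbon), made a step of a 1.2-fold higher number from compound 1 to compound 2 (0.09 log units; within the scatter). Compound 3 `Fc1cccc2c1nnn2CC1CC1` gives 1070 nM in this assay, the highest of the three numbers. How the core of compound 3 differs from the core of compound 1 is not broken down here. Compound 4 `N#Cc1cccc2c1nnn2CC1CC1` has not yet been measured in this assay; it arises from compound 3 by cyano in place of fluoro on an aromatic carbon, the same change as that from compound 1 to compound 2, at a place described in the same words. Because a 1.2-fold higher number from compound 1 to compound 2 (0.09 log units; within the scatter) lay within the scatter, the expected step is a 1.2-fold higher number from compound 3 to compound 4 (0.08 log units; within the scatter). Compound 4 is estimated at 1300 nM in this assay, with a likely range from 500 nM to 3500 nM.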

Compound 4, half-maximal effective concentration: 620 nM
Estimate against measurement, compound 4: 2.1-fold (0.32 log units) above, and the stated range covers the measured number.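

Cyano in place of fluoro on an aromatic carbon gave a 1.7-fold lower number from compound 3 to compound 4 (0.24 log units; within the scatter) in this assay. Set beside the earlier step, the change carried over to the second core with no difference that can be told from the scatter: the same change on two cores in this assay, a 1.2-fold higher number (0.09 log units; within the scatter) from compound 1 to compound 2 and a 1.7-fold lower number (0.24 log units; within the scatter) from compound 3 to compound 4, 2.1-fold (0.32 log units) apart, within the scatter of two such steps. Going by these compounds alone, this shows only that the swap made no readable difference on these two cores; it does not show that the same would hold on any further core, and two pairs make no general rule.

The compounds shown leave open what other groups on this aromatic carbon would do, such as an amine or a carboxylic acid. They also leave open whether a group larger than cyano would be carried across the two cores in the same way.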